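Inverting one stereocentre at the limit of the assay

The source may hold more compounds than are shown below. What is called first, only, known or untested is meant among the compounds shown, and "the series" means these compounds.

Values in a functional assay on MCF7 cells (Homo sapiens) for antiproliferative activity, read by MTT assay, with a stated time of 24 h; on this read-out higher numbers stand for weaker inhibition and lower numbers for stronger inhibition:
- compound 1 `CCn1c(C(=O)NCCNC(=O)OC(C)(C)C)ccc1C(CC)(CC)c1ccc(OCS(=O)(=O)c2ccccc2)c(C)c1`: > 50000 nM, a limit
- compound 2 `CCn1c(C(=O)N[C@H](CO)CCCO)ccc1C(CC)(CC)c1ccc(OCS(=O)(=O)c2ccccc2)c(C)c1`: 31400 nM
- compound 3 `CCn1c(C(=O)N[C@@H](CC(=O)O)C(=O)O)ccc1C(CC)(CC)c1ccc(OCS(=O)(=O)c2ccccc2)c(C)c1`: > 50000 nM, a limit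

Compound 3 reads > 50000 nM, which is a limit and not a number. Going by the values given here, the series so far shows (the limit of > 50000 nM in this assay, at which 2 of the 3 values shown sit).

Compound 4 `CCn1c(C(=O)N[C@H](CC(=O)O)C(=O)O)ccc1C(CC)(CC)c1ccc(OCS(=O)(=O)c2ccccc2)c(C)c1` is the unmeasured partner of compound 3: the two compounds have the same atoms and bonds and differ only in configuration as drawn: 1 of 1 stereo elements differ; a stereocentre at a saturated chain carbon is drawn S in compound 3 and R in compound 4.

The measured steps bear on this only indirectly, since each changes the group on the amide-type nitrogen and none changes configuration alone. The series shows an at least 1.5-fold lower number from compound 1 to compound 2 (0.20 log units; that floor lies within the scatter), and it shows an at least 1.5-fold higher number from compound 2 to compound 3 (0.20 log units; that floor lies within the scatter). It also shows a step that the two limits leave unreadable from compound 1 to compound 3. Among the compounds with values here, no measured pair tests an inversion, so no step beyond the scatter is expected in this assay, and no direction is favoured.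

Within the data shown here, compound 2 gives the only number, 31400 nM, and any number expected for the inverted compound lies in that region. The expected outcome is a number no higher from compound 3 to compound 4 (the limit leaves the size open). For compound 4 the estimate is 50000 nM, with an expected range from 25000 nM to 100000 nM.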

Compound 4, half-maximal inhibitory concentration: > 50000 nM
Compound 4: only a limit was reported; the forecaster's own chance of this, stated with the estimate: 75%; the middle value lies on the limit itself.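

In this assay compound 4 gives > 50000 nM, which is a limit and not a number. Both configurations of the 1,2-dicarboxyethyl group on the amide-type nitrogen now sit at the same limit, so inverting this stereocentre brings no readable value in either form, and the steps that end in two limits cannot be read: the limit of > 50000 nM in this assay, at which 3 of the 4 values shown sit. Going by these compounds alone, the one readable comparison is with the hydroxyl-bearing compound 2, which shows an at least 1.5-fold higher number from compound 2 to compound 4 (0.20 log units; that floor lies within the scatter) and so adds no separation beyond the scatter.

From the compounds shown here alone, whether compound 3 and compound 4 differ at all stays open, as neither gives a number: the fact that compounds 3 and 4 differ only in the configuration as drawn. Also open, going by these compounds, is whether an amine or a longer chain in place of 1,2-dicarboxyethyl on the amide-type nitrogen would give a value inside the range of this assay.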